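Replacing a Piperazine With an Open Acid Chain

This account rests on a few compounds, and the source may have more. Where it says the series, first, only, none or still open, it means among the compounds named here.

Measured compounds:
Compound 1, `COC(=O)C1=C(CN2CCNCC2)NC(c2nccs2)=NC1(C)c1ccc(F)cc1`: 250 ug/mL
Compound 2, `COC(=O)C1=C(CN2CCC(O)CC2)NC(c2nccs2)=NC1(C)c1ccc(F)cc1`: 593 ug/mL
Compound 3, `COC(=O)C1=C(CN2CCC(O)C2)NC(c2nccs2)=NC1(C)c1ccc(F)cc1`: 503 ug/mL

In a physicochemical assay for solubility, read by HPLC, in phosphate buffer, at pH 6.5 (on this read-out higher numbers stand for higher solubility and lower numbers for lower solubility), compound 1 gives the lowest of the three numbers. Compound 2 stands furthest from it, with a 2.4-fold higher number from compound 1 to compound 2 (0.38 log units; beyond the scatter). Compound 3 stands nearest, with a 2.0-fold higher number from compound 1 to compound 3 (0.30 log units; within the scatter); between compound 2 and compound 3 the difference is a 1.2-fold lower number from compound 2 to compound 3 (0.07 log units; within the scatter).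

The unmeasured compound 4, `COC(=O)C1=C(COC(C(=O)O)C(F)(F)F)NC(c2nccs2)=NC1(C)c1ccc(F)cc1`, differs from compound 1 in one place: a group of 9 heavy atoms (3 carbon, 3 oxygen, 3 fluorine; no ring) in place of a group of 6 heavy atoms (4 carbon, 2 nitrogen; one six-membered non-aromatic ring with 2 hetero atoms), on a saturated chain carbon bound to a double-bonded ring carbon

Two measured steps leave the same group from the same place, but what enters in those steps is a ring bearing a hydroxyl, while in compound 4 an open chain enters. Among the compounds with values here, the steps of a 2.4-fold higher number from compound 1 to compound 2 (0.38 log units; beyond the scatter) and a 2.0-fold higher number from compound 1 to compound 3 (0.30 log units; within the scatter) therefore bear on the step to compound 4 only loosely, and no measured pair shows a change of this kind. Within the data shown here, the one thing the measured steps share is that leaving piperazin-1-yl did not lower the number. Compound 4 is accordingly expected to stay close to compound 1, with a 1.2-fold higher number from compound 1 to compound 4 (0.08 log units; within the scatter), and with a wide range on either side. The estimate for compound 4 in this assay is 300 ug/mL, between 80 ug/mL and 1200 ug/mL.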

Compound 4, solubility: > 649 ug/mL
Compound 4: only a limit was reported; the forecaster's own chance of this, stated with the estimate: 10%; at least 2.1-fold (0.33 log units) between middle value and limit.
By their numbers in this assay, from the lowest: compounds 1, 3 and 2 (each within the scatter of the next, the first and the last beyond it). At a limit, above all of these: compound 4.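

In this assay, compound 4 carries only a limit and not a number: the limit of > 649 ug/mL in this assay, at which 1 of the 4 values shown sits. Even so, the place on a saturated chain carbon bound to a double-bonded ring carbon now proves to accept an open chain with no ring and no nitrogen in place of piperazin-1-yl, with an at least 2.5-fold higher number from compound 1 to compound 4 (0.41 log units; beyond the scatter), so the ring amine of compound 1 is not needed for the higher numbers seen at this place. Against the two hydroxyl-bearing rings the result says less: the steps are an at least 1.2-fold higher number from compound 3 to compound 4 (0.11 log units; that floor lies within the scatter) and an at least 1.0-fold higher number from compound 2 to compound 4 (0.03 log units; that floor lies within the scatter), so neither floor separates the open chain from those rings, though the real gaps could be wider.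

The compounds shown leave open how far the true number lies past the limit, and they do not separate what the carboxylic acid and the trifluoromethyl group each contribute to the step. How an open chain ending in an amine, or the same chain keeping its carboxylic acid but without the trifluoromethyl group, would read at this place remains an open question.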